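A few compounds are considered here, and "the series" means these few. Any claim that something is new, unique, unknown or untested is made for them only; others in the source may bear on it.

Measured so far:
compound 1 `CC(C)c1noc(N2CCN(C(=O)[C@@H]3CCCN(S(=O)(=O)c4ccc(S(=O)(=O)C(C)C)cc4)C3)CC2)n1` gives 30 nM
compound 2 `CCOC(=O)[C@@H]1CCCN(S(=O)(=O)c2ccc(S(=O)(=O)N(CC)C(C)C)cc2)C1` gives 1200 nM

In a functional assay on MIA PaCa-2 cells (Homo sapiens) for inhibition, read by MTT assay, with a stated time of 3 days (on this read-out higher numbers stand for weaker inhibition and lower numbers for stronger inhibition), compound 2 stands at the highest of the two numbers; the only other, compound 1, lies far lower, beyond the scatter. Compound 3 `CCOC(=O)[C@@H]1CCCN(S(=O)(=O)c2ccc(S(=N)(=O)N(CC)CC)cc2)C1` keeps the core of compound 2 and differs by a group of 8 heavy atoms (4 carbon, 2 nitrogen, 1 oxygen, 1 sulfur; no ring) in place of a group of 9 heavy atoms (5 carbon, 1 nitrogen, 2 oxygen, 1 sulfur; no ring), on an aromatic carbon. For the measured compounds named here, no measured pair shows a change of this kind, so its effect is unknown. The step from compound 2 to compound 3 is expected to be small, in no clear direction, and not beyond the scatter: a 1.2-fold higher number from compound 2 to compound 3 (0.07 log units; within the scatter). Compound 3 is expected to give 1400 nM, in the range 450 nM to 4500 nM.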

Compound 3, half-maximal inhibitory concentration: 900 nM
Compound 3: the middle estimate sits 1.6-fold (0.19 log units) above what was measured; the range from low to high includes it.
By their numbers in this assay, from the lowest: compound 1; then compounds 3 and 2 (each within the scatter of the next).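

In this assay, on an aromatic carbon para to a large group, the ethyl(isopropyl)sulfamoyl group gives way to a group with a hydrogen-bond donor, and the result is a 1.3-fold lower number from compound 2 to compound 3 (0.12 log units; within the scatter), so this position accepts that replacement on the core of compound 2 with no change beyond the scatter. Nothing available explains this outcome.

On these data alone, what a primary sulfonamide or a methyl sulfone would do at this position remains open. Also open, as far as these compounds go, is whether the same replacement holds on the core of compound 1.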